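Changing the aryl group on a hydrazone-linked urea series

The source may report more compounds than this note shows. Statements on the series, on what has been measured and on what is new or still open speak of the compounds shown alone.

Measured compounds:
compound 1 `CN(C)CCn1cnnc1-c1cc(Oc2ccc(NC(=O)N/N=C/c3cccc(Br)c3)cc2F)ccn1`: 520 nM
compound 2 `CN(C)CCn1cnnc1-c1cc(Oc2ccc(NC(=O)N/N=C/c3ccc(F)cc3Cl)cc2F)ccn1`: 720 nM
compound 3 `CN(C)CCn1cnnc1-c1cc(Oc2ccc(NC(=O)N/N=C/c3ccc(Cl)cc3)cc2F)ccn1`: 320 nM

All three share one core and differ only in the aryl group attached to the carbon with a double bond to nitrogen. In a functional assay on NCI-H460 cells (Homo sapiens) for cytotoxicity, read by MTT assay, with a stated time of 72 h (on this read-out higher numbers stand for weaker inhibition and lower numbers for stronger inhibition), compound 1 gives 520 nM, the second highest of the three numbers; its nearest neighbour is compound 2 a 1.4-fold higher number from compound 1 to compound 2 (0.14 log units; within the scatter) and its furthest is compound 3 a 1.6-fold lower number from compound 1 to compound 3 (0.21 log units; within the scatter), both within the scatter. For the measured compounds named here, the only step beyond the scatter is a 2.3-fold lower number from compound 2 to compound 3 (0.35 log units; beyond the scatter), a modest one.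

Compound 4 `CN(C)CCn1cnnc1-c1cc(Oc2ccc(NC(=O)N/N=C/c3c(O)ccc4ccccc34)cc2F)ccn1` arises from compound 1 by this change: 2-hydroxynaphthalen-1-yl in place of 3-bromophenyl on a carbon with a double bond to nitrogen. The entering group is larger and brings a hydrogen-bond donor and acceptor where none was before, so the measured steps are only loosely related; all three aryl swaps moved the number little. The expectation is therefore a step of a 1.0-fold lower number from compound 1 to compound 4 (0.02 log units; within the scatter), within or barely beyond the scatter, and compound 4 is estimated at 500 nM with a range from 180 nM to 1500 nM.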

Compound 4, half-maximal inhibitory concentration: 890 nM
Beside the measured number, compound 4's estimate is 1.8-fold (0.25 log units) below it, within the range that was stated.
By their numbers in this assay, from the lowest: compounds 3, 1, 2 and 4 (each within the scatter of the next, the first and the last beyond it).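

Swapping a single ring for the two-ring 2-hydroxynaphthalen-1-yl, which brings a hydrogen-bond donor and acceptor, leaves the number in this assay within the scatter of two halogen-bearing aryl groups: the steps are a 1.7-fold higher number from compound 1 to compound 4 (0.23 log units; within the scatter) and a 1.2-fold higher number from compound 2 to compound 4 (0.09 log units; within the scatter). So this position on the carbon with a double bond to nitrogen accepts a clearly larger group with a hydroxyl, and the number stays in the range already seen. Only the comparison with 4-chlorophenyl goes beyond the scatter, with a 2.8-fold higher number from compound 3 to compound 4 (0.44 log units; beyond the scatter), a modest step. No available measurement bears on the reason for these differences.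

From the compounds shown here alone, the second ring and the hydroxyl enter together in one change, so their separate contributions remain open; naphthalen-1-yl without the hydroxyl, or 2-hydroxyphenyl, would pull them apart. Also open, going by these compounds, is how an aryl group carrying an amine or a carboxylic acid would behave here.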